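A few compounds are considered here, and "the series" means these few. Any claim that something is new, unique, unknown or untested is made for them only; others in the source may bear on it.

Measured compounds:
compound 1 `CC/C=C\C(=O)Nc1cc(Nc2nc3c(c(-c4cn(C)c5ccc(F)cc45)n2)CSCC3)c(OC)cc1N(C)CCN(C)C` — 1450 nM
compound 2 `CCC/C=C\C(=O)Nc1cc(Nc2nc3c(c(-c4cn(C)c5ccc(F)cc45)n2)CSCC3)c(OC)cc1N(C)CCN(C)C` — 5190 nM
compound 3 `C/C=C\C(=O)Nc1cc(Nc2nc3c(c(-c4cn(C)c5ccccc45)n2)CS(=O)(=O)CC3)c(OC)cc1N(C)CCN(C)C` — 4260 nM

In a functional assay on A549 cells (Homo sapiens) for inhibition, read by MTT assay, with a stated time of 72 h (on this read-out higher numbers stand for weaker inhibition and lower numbers for stronger inhibition), compound 1 gives 1450 nM and compound 2 gives 5190 nM. The change between them, (methyl in place of hydrogen on a saturated chain carbon, two bonds along the chain from a double-bonded chain carbon), produced a 3.6-fold higher number from compound 1 to compound 2 (0.55 log units; beyond the scatter). Compound 3 gives 4260 nM in this assay; its value and that of compound 2 fall within the usual scatter of each other, while compound 1 stands clearly lower. The difference between the core of compound 3 and the core of compound 1 is not broken down here.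

Compound 4 `CC/C=C\C(=O)Nc1cc(Nc2nc3c(c(-c4cn(C)c5ccccc45)n2)CS(=O)(=O)CC3)c(OC)cc1N(C)CCN(C)C` is not yet measured. It differs from compound 3 by methyl in place of hydrogen on a saturated chain carbon bound to a double-bonded chain carbon, which is the same kind of change as that from compound 1 to compound 2, though the place differs: there the methyl enters on a saturated chain carbon two bonds along the chain from a double-bonded chain carbon, here on a saturated chain carbon bound to a double-bonded chain carbon. Resting on compound 1 and compound 2, whose step was a 3.6-fold higher number from compound 1 to compound 2 (0.55 log units; beyond the scatter), a step of roughly a 2.1-fold higher number from compound 3 to compound 4 (0.32 log units; beyond the scatter) is expected for compound 4 in this assay. Compound 4 is therefore estimated at 9000 nM, between 4000 nM and 25000 nM.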

Compound 4, half-maximal inhibitory concentration: 1350 nM
The estimate for compound 4 lay 6.7-fold (0.82 log units) above the measured number; the whole stated range lies above it.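

In this assay, the methyl that turns prop-1-en-1-yl into but-1-en-1-yl gives a 3.2-fold lower number from compound 3 to compound 4 (0.50 log units; beyond the scatter), so the rise in the number seen on the core of compound 1 does not recur on the core of compound 3, and the two steps run in opposite directions: the same change on two cores in this assay, a 3.6-fold higher number (0.55 log units; beyond the scatter) from compound 1 to compound 2 and a 3.2-fold lower number (0.50 log units; beyond the scatter) from compound 3 to compound 4, 11-fold (1.05 log units) apart, beyond the scatter of two such steps This shows that, among these compounds, neither the size nor the direction of a step from adding a methyl to this chain can be carried from one core to the other. It does not show what sets the two steps apart, since they differ in the core and also in where the methyl enters, and each rests on a single pair of compounds.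

As far as these compounds go, what a longer chain would do on the core of compound 3, and what prop-1-en-1-yl would do on the core of compound 1, remains open. Either comparison would help separate the part played by the core from that played by the place of the methyl.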